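Ketooxazole series: carbamoylpyridyl replacement on the oxazole

The compounds below may be only part of what the source reports. "The series", "measured", "known", "first", "only" and "open" are said of these compounds alone.

Measured so far:
compound 1 `Nc1ccc(-c2cnc(C(=O)CCCCCCc3ccccc3)o2)cc1` — 90 nM
compound 2 `Cc1cccc(-c2cnc(C(=O)CCCCCCc3ccccc3)o2)n1` — 3.3 nM
compound 3 `COc1ccnc(-c2cnc(C(=O)CCCCCCc3ccccc3)o2)c1` — 0.8 nM

All three share the same core carrying the phenyl-terminated ketone chain; they differ only in the aryl group on the oxazole carbon. In an assay (Rattus norvegicus) for inhibition of Fatty-acid amide hydrolase 1 (Homo sapiens) (on this read-out higher numbers stand for weaker inhibition and lower numbers for stronger inhibition), compound 3 gives the lowest number of the three: the nearest is compound 2, and the gap a 4.1-fold lower number from compound 2 to compound 3 (0.62 log units; beyond the scatter) is beyond the scatter; the furthest is compound 1, with a 110-fold lower number from compound 1 to compound 3 (2.05 log units; beyond the scatter).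

Compound 4 `NC(=O)c1ccc(-c2cnc(C(=O)CCCCCCc3ccccc3)o2)nc1` is unmeasured. Its change from compound 3 is 5-carbamoylpyridin-2-yl in place of 4-methoxypyridin-2-yl on an aromatic carbon. The step that bears most directly on it is a 4.1-fold lower number from compound 2 to compound 3 (0.62 log units; beyond the scatter), where the substituent on the pyridin-2-yl group was exchanged and the number moved modestly. The larger steps of a 27-fold lower number from compound 1 to compound 2 (1.44 log units; beyond the scatter) and a 110-fold lower number from compound 1 to compound 3 (2.05 log units; beyond the scatter) show that leaving 4-aminophenyl for a pyridin-2-yl group gave the big gains; compound 4 keeps the pyridin-2-yl group, so a change of that size is not expected here. A modest step in this assay is expected, most likely toward a higher number, as the 4-methoxy group left and the carbamoyl group entered, bringing a hydrogen-bond donor.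

Compound 4 is therefore estimated at 2.5 nM, range 0.6 nM to 10 nM, corresponding to an expected step of a 3.1-fold higher number from compound 3 to compound 4 (0.49 log units; beyond the scatter).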

Compound 4, inhibition constant: 1.2 nM
For compound 4 the middle estimate is 2.1-fold (0.32 log units) above the measured one; measured number inside the range.
By their numbers in this assay, from the lowest: compounds 3 and 4 (each within the scatter of the next); then compound 2; then compound 1.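

In this assay, the exchange of 4-methoxypyridin-2-yl for 5-carbamoylpyridin-2-yl on the aromatic carbon next to the ring oxygen shows no change beyond the scatter, a 1.5-fold higher number from compound 3 to compound 4 (0.18 log units; within the scatter), even though the entering group carries a hydrogen-bond donor and the leaving group carries none. Compound 2 is separated from the new compound by a modest step, a 2.8-fold lower number from compound 2 to compound 4 (0.44 log units; beyond the scatter), and the large step from the aminophenyl compound persists, a 75-fold lower number from compound 1 to compound 4 (1.88 log units; beyond the scatter), so two differently substituted pyridin-2-yl groups now sit beyond the scatter from both 6-methylpyridin-2-yl and 4-aminophenyl. The step from compound 3 changes both the substituent and its place on the pyridine ring, so these numbers do not separate the contribution of the group from that of its location.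

Nothing shown here gives a measured reason for this result. Still open, from the compounds shown here alone, is whether a nitrile, a carboxylic acid or a methyl ester in place of the carbamoyl group, or a methoxy group in the 5-position of the pyridin-2-yl ring, would stay within the scatter of compound 4.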